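This account rests on a few compounds, and the source may have more. Where it says the series, first, only, none or still open, it means among the compounds named here.

Compound 3, with the structure `Cc1ccccc1C(=O)Nc1ccc(S(=O)(=O)NC2CCN(C(=O)CN)CC2)c2ccccc12`, gives 4.1 nM in an assay on L1.2 cells for binding affinity to C-C chemokine receptor type 8 (Homo sapiens); on this read-out higher numbers stand for weaker inhibition and lower numbers for stronger inhibition. That puts compound 3 second highest of the three numbers measured in this assay: its nearest neighbour is compound 1, `CCC(=O)N1CCC(NS(=O)(=O)c2ccc(NC(=O)c3ccccc3C)c3ccccc23)CC1`, which gives 2.5 nM, the step of a 1.6-fold higher number from compound 1 to compound 3 (0.21 log units; within the scatter) staying within the scatter; its furthest is compound 2, `COCC(=O)N1CCC(NS(=O)(=O)c2ccc(NC(=O)c3ccccc3C)c3ccccc23)CC1`, which gives 15.8 nM, the step of a 3.9-fold lower number from compound 2 to compound 3 (0.59 log units; beyond the scatter) lying beyond it.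

Compound 4, `Cc1ccccc1C(=O)Nc1ccc(S(=O)(=O)NC2CCN(C(=O)CCCN)CC2)c2ccccc12`, carries 2-aminoethyl in place of amino on a saturated chain carbon bound to a carbonyl carbon. All three measured steps concern the same place but swap one group for another: a 6.3-fold higher number from compound 1 to compound 2 (0.80 log units; beyond the scatter), a 1.6-fold higher number from compound 1 to compound 3 (0.21 log units; within the scatter) and a 3.9-fold lower number from compound 2 to compound 3 (0.59 log units; beyond the scatter). The amino group and the methyl group sit within the scatter of each other, and only the methoxy variant moves the number modestly. For the measured compounds named here, no measured step lengthens the chain while keeping the amino group, so the bearing of these steps on compound 4 is indirect. The estimate for compound 4 is therefore a step of a 1.2-fold higher number from compound 3 to compound 4 (0.09 log units; within the scatter), no larger than the scatter in either direction. Compound 4 is expected to give about 5 nM, with a range from 1.8 nM to 14 nM.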

Compound 4, inhibition constant: 1.6 nM
Beside the measured number, compound 4's estimate is 3.1-fold (0.49 log units) above it; measured number outside the range, below it.
By their numbers in this assay, from the lowest: compounds 4, 1 and 3 (each within the scatter of the next, the first and the last beyond it); then compound 2.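

For the compounds shown here, at this place, on a saturated chain carbon bound to a carbonyl carbon, 2-aminoethyl in place of amino gives the first step in this assay that lengthens the chain while keeping the amino group, and it goes to a lower number (a 2.6-fold lower number from compound 3 to compound 4 (0.41 log units; beyond the scatter)). Read instead as aminomethyl in place of hydrogen, the same structure stays level with the shorter unsubstituted chain (a 1.6-fold lower number from compound 1 to compound 4 (0.19 log units; within the scatter)), so the longer amine-bearing chain is not separated from compound 1 beyond the scatter. The methoxy variant stands further apart from the longer amine-bearing chain (a 9.9-fold lower number from compound 2 to compound 4 (0.99 log units; beyond the scatter)) than from any other compound shown.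

Going by these compounds, whether a longer chain ending in an amine, or a carboxylic acid in place of the amine, would hold this number remains open. Nothing shown here explains the size of these steps.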